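The source may report more compounds than this note shows. Statements on the series, on what has been measured and on what is new or still open speak of the compounds shown alone.

Compound 1 `Cc1ccc(-c2ccc(F)cc2)n1-c1ccc(-c2nc3ccccc3s2)cc1`, compound 2 `COc1ccc(-c2ccc(C)n2-c2ccc(-c3nc4ccccc4s3)cc2)cc1` and compound 3 `Cc1ccc(-c2ccc([N+](=O)[O-])cc2)n1-c1ccc(-c2nc3ccccc3s2)cc1` share one core and differ only in the group carried on the outer aromatic ring. In a functional assay on MCF7 cells (Homo sapiens) for cytotoxicity, read by sulforhodamine B assay, with a stated time of 48 h (a lower number here means a stronger inhibitor of growth, a higher number a weaker inhibitor of growth), compound 1 gives 2620 nM, compound 2 gives 2780 nM and compound 3 gives 2540 nM. The three numbers sit close together: a 1.1-fold higher number from compound 1 to compound 2 (0.03 log units; within the scatter), a 1.0-fold lower number from compound 1 to compound 3 (0.01 log units; within the scatter) and a 1.1-fold lower number from compound 2 to compound 3 (0.04 log units; within the scatter). Compound 3 thus stands within the scatter of both of its neighbours, and none of the three can be set apart from the others.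

Compound 4 `COc1ccc2nc(-c3ccc(-n4c(C)ccc4-c4ccc([N+](=O)[O-])cc4)cc3)sc2c1` keeps the nitro-bearing ring of compound 3 and changes a different part of the molecule: methoxy in place of hydrogen on an aromatic carbon. For the measured compounds named here, none of the measured steps touches this place; all three exchange the group on the outer ring and all three lie within the scatter. The measured steps therefore say only that this series has so far been flat, and they give no direct guide to a change on the fused ring. On that basis the step from compound 3 to compound 4 in this assay is expected to be small, a 1.0-fold higher number from compound 3 to compound 4 (0.01 log units; within the scatter), with no clear direction. Compound 4 is estimated to give 2600 nM in this assay, within a range from 1300 nM to 5200 nM.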

Compound 4, concentration for 50% growth inhibition: 3170 nM
Estimate against measurement, compound 4: 1.2-fold (0.09 log units) below, within the range that was stated.
By their numbers in this assay, from the lowest: compounds 3, 1, 2 and 4 (each within the scatter of the next).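

The fused ring system now has a measured step of its own: with the nitro-bearing outer ring held constant, methoxy in place of hydrogen on an aromatic carbon gives a 1.2-fold higher number from compound 3 to compound 4 (0.10 log units; within the scatter) in this assay. The flat behaviour seen so far for exchanges on the outer ring therefore also holds, for this one pair, at a second place in the molecule, and this place shows no measurable response to this one exchange. Nothing available bears on why the numbers stay so close together.

The compounds shown leave open whether another group at this place, such as an amine, a carboxylic acid or a longer alkoxy chain, would stay as flat, and whether methoxy here would act the same way alongside the fluoro ring of compound 1 or the methoxy ring of compound 2. They also leave open whether any change elsewhere on the shared core could produce a step beyond the scatter in this assay, given that every step shown so far lies within it.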